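Swapping the butylamino of compound 2 for dimethylamino

The source may hold more compounds than are shown below. What is called first, only, known or untested is meant among the compounds shown, and "the series" means these compounds.

Measured compounds:
- compound 1 `CCCNc1nc(NCc2ccc(C(=O)Nc3ccc(F)cc3)cc2)c2ccccc2n1`: 1500 nM
- compound 2 `CCCCNc1nc(NCc2ccc(C(=O)Nc3ccc(F)cc3)cc2)c2ccccc2n1`: 1400 nM

In a functional assay on HCT-116 cells (Homo sapiens) for inhibition, read by luminescence and resazurin assay, with a stated time of 3 days (on this read-out higher numbers stand for weaker inhibition and lower numbers for stronger inhibition), compound 2 gives the lowest of the two numbers, though its nearest neighbour, compound 1, sits within the scatter, so no order between them can be claimed. Going by the values given here, the only measured step, a 1.1-fold lower number from compound 1 to compound 2 (0.03 log units; within the scatter), concerns a lengthening of the chain and is within the scatter.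

Compound 3 `CN(C)c1nc(NCc2ccc(C(=O)Nc3ccc(F)cc3)cc2)c2ccccc2n1` differs from compound 2 by dimethylamino in place of butylamino on an aromatic carbon. Among the compounds with values here, no measured step exchanges a chain-bearing amino group for one without a hydrogen-bond donor, so the chain-lengthening step gives no direct guide, and the change is of a different kind. Compound 3 is therefore expected to give a somewhat higher number in this assay, with wide uncertainty, an estimated step of a 2.1-fold higher number from compound 2 to compound 3 (0.33 log units; beyond the scatter). The estimate for compound 3 is 3000 nM, within a range from 900 nM to 10000 nM.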

Compound 3, half-maximal inhibitory concentration: 1900 nM
For compound 3 the middle estimate is 1.6-fold (0.20 log units) above the measured one; the range from low to high includes it.
By their numbers in this assay, from the lowest: compounds 2, 1 and 3 (each within the scatter of the next).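

In this assay, exchanging the chain for dimethylamino gives small steps in both comparisons (a 1.4-fold higher number from compound 2 to compound 3 (0.13 log units; within the scatter)) and (a 1.3-fold higher number from compound 1 to compound 3 (0.10 log units; within the scatter)), and both lie within the scatter. On this aromatic carbon between two ring nitrogen atoms, then, dimethylamino, with 0 hydrogen-bond donors, cannot be told apart from butylamino or propylamino, which each keep 1 hydrogen-bond donor, so these three compounds show no requirement at this position for that donor or for a chain. Nothing available explains this result.

As far as these compounds go, it remains open whether a ring amine such as morpholine or piperidine, a much longer chain or a chain ending in a carboxylic acid would move the number beyond the scatter. The compounds shown also leave open whether the plain amino group would do so.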